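This account rests on a few compounds, and the source may have more. Where it says the series, first, only, none or still open, it means among the compounds named here.

Measured so far in a functional assay on HCT-8 cells (Homo sapiens) for cytotoxicity, read by MTT assay, with a stated time of 48 h; on this read-out higher numbers stand for weaker inhibition and lower numbers for stronger inhibition:
- compound 1 `COc1cc(C(=O)NC2CCN(C)CC2)ccc1Nc1ncc(Br)c(NC2CCCC2)n1`: 12000 nM
- compound 2 `CN1CCC(NC(=O)c2ccc(Nc3ncc(F)c(NC4CCCC4)n3)cc2)CC1`: 16000 nM
- compound 3 `CN1CCC(NC(=O)c2ccc(Nc3ncc(Cl)c(NC4CCCC4)n3)cc2)CC1`: 4600 nM

Compound 3 gives the lowest number of the three in this assay; compound 1 sits at a higher number, and compound 2 higher still, both gaps beyond the scatter. The one step among these that changes a single place is a 3.5-fold lower number from compound 2 to compound 3 (0.54 log units; beyond the scatter), the fluoro-to-chloro exchange on the aromatic carbon.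

Compound 4 `CN1CCC(NC(=O)c2ccc(Nc3ncc(Br)c(NC4CCCC4)n3)cc2)CC1` has not yet been measured. It differs from compound 3 by bromo in place of chloro on an aromatic carbon. Within the data shown here, no measured pair in this set isolates that exchange: compound 1 also carries bromo at the same position, but it differs from compound 3 in a second place as well, so the value of compound 1, 12000 nM, against the value of compound 3, 4600 nM, cannot be read as the bromo effect alone. Among the measured compounds shown here, the only bearing evidence is the fluoro-to-chloro step, which lowered the number modestly; the continuation to bromo is expected to give at most a small further lowering, likely within the scatter, as a 1.3-fold lower number from compound 3 to compound 4 (0.12 log units; within the scatter). Compound 4 is therefore estimated at 3500 nM in this assay, with a range of 1500 nM to 9000 nM.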

Compound 4, half-maximal inhibitory concentration: 3600 nM
The estimate for compound 4 lay 1.0-fold (0.01 log units) below the measured number, within the range that was stated.
By their numbers in this assay, from the lowest: compounds 4 and 3 (each within the scatter of the next); then compounds 1 and 2 (each within the scatter of the next).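

Notes on the halogen position, read in this assay: the exchange on the aromatic carbon ortho to the cyclopentylamino group now has its first direct reading for bromo against chloro, and a 1.3-fold lower number from compound 3 to compound 4 (0.11 log units; within the scatter) shows that the two halogens cannot be told apart here. Fluoro stands apart from both, since the bromo compound adds a second step beyond the scatter, a 4.4-fold lower number from compound 2 to compound 4 (0.65 log units; beyond the scatter) and this matches the earlier reading for chloro. With bromo held constant, the series also gains its first single-place reading of the methoxy group, a 3.3-fold lower number from compound 1 to compound 4 (0.52 log units; beyond the scatter) and this separates the methoxy change from the halogen exchange that could not be isolated before; no measurement available here explains any of these steps.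

Still open, from the compounds shown here alone, is whether the flat reading from chloro to bromo extends to iodo, or whether a methyl, trifluoromethyl or nitrile group on the same aromatic carbon would behave like fluoro or like the heavier halogens. Also open, going by these compounds, is whether the methoxy step recurs with chloro or fluoro on the core, and whether any of these readings hold with a cyclohexylamino group in place of the cyclopentylamino group.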